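From ethyl to 4-fluorophenyl on the aromatic nitrogen

The compounds below may be only part of what the source reports. "The series", "measured", "known", "first", "only" and "open" are said of these compounds alone.

Compound 1 `CCn1ccnc1-c1cc(OC)c(OC)c(OC)c1` carries an ethyl on an aromatic nitrogen of the shared core. In a functional assay on MDA-MB-231 cells (Homo sapiens) for antiproliferative activity, read by MTT assay, with a stated time of 72 h (a lower number here means a stronger inhibitor, a higher number a weaker inhibitor), compound 1 returns only a limit of the assay, > 100000 nM. That value sits at the limit of > 100000 nM in this assay, at which 1 of the 2 values shown sits. Compound 2 `COc1cc(-c2nccn2-c2ccc3sccc3c2)cc(OC)c1OC` gives 16800 nM in this assay. Compound 3 `COc1cc(-c2nccn2-c2ccc(F)cc2)cc(OC)c1OC` has not been measured and differs from compound 1 by 4-fluorophenyl in place of ethyl on an aromatic nitrogen. A move toward stronger inhibition, well beyond the usual scatter, is expected, an at least 5.0-fold lower number from compound 1 to compound 3 (0.69 log units; beyond the scatter). Compound 3 is estimated to give 20000 nM in this assay, within a range from 5000 nM to 80000 nM.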

Compound 3, half-maximal inhibitory concentration: 38400 nM
Estimate against measurement, compound 3: 1.9-fold (0.28 log units) below; low and high end bracket the measured number.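

In this assay, 4-fluorophenyl in place of ethyl on an aromatic nitrogen gives an at least 2.6-fold lower number from compound 1 to compound 3 (0.41 log units; beyond the scatter). At this position, a six-membered aromatic ring of carbon bearing fluorine thus gives a measured number, where the ethyl of compound 1 gave only a limit. Only a lower bound on the size of this step can be read: the limit of > 100000 nM in this assay, at which 1 of the 3 values shown sits.

The compounds shown leave open whether the ring alone or the fluorine on it accounts for the step, with plain phenyl absent from them. They also leave open how an amine or a longer chain would read on this nitrogen.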